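Bromo to fluoro: the step to compound 4

This account rests on a few compounds, and the source may have more. Where it says the series, first, only, none or still open, it means among the compounds named here.

Measured in an ADME assay on TERT-RPE1 cells (Homo sapiens) for cytotoxicity, read by MTT assay, with a stated time of 72 h (on this read-out higher numbers stand for weaker inhibition and lower numbers for stronger inhibition), as follows:
compound 1 `C=CC/N=C1\S/C(=C\c2ccc(OC)cc2)C(=O)N1C`: > 100000 nM (a limit)
compound 2 `COc1ccc(/C=C2\S/C(=N\c3ccc(C(C)(C)C)cc3)N(C)C2=O)cc1`: 46700 nM
compound 3 `COc1ccc(/C=C2\S/C(=N\c3ccc(Br)cc3)N(C)C2=O)cc1`: > 100000 nM (a limit)

Compound 3 sits at the limit of > 100000 nM in this assay, at which 2 of the 3 values shown sit, and its > 100000 nM is a limit and not a number. Compound 4 `COc1ccc(/C=C2\S/C(=N\c3ccc(F)cc3)N(C)C2=O)cc1` differs from it in a single place, (fluoro in place of bromo on an aromatic carbon), with fluoro in place of bromo on an aromatic carbon, para to a large group. The step that bears most closely is an at least 2.1-fold higher number from compound 2 to compound 3 (0.33 log units; beyond the scatter), with bromo in place of tert-butyl on an aromatic carbon. The other step, a step that the two limits leave unreadable from compound 1 to compound 3, gives no size. Neither step exchanges bromo for fluoro. With compound 3 at > 100000 nM, a limit, compound 4 is expected to stay close to that limit and may again be reported only as a limit. The estimated step is a number no higher from compound 3 to compound 4 (the limit leaves the size open) in this assay, with no clear direction expected. In this assay the estimate for compound 4 is 100000 nM, with an expected range from 50000 nM to 200000 nM.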

Compound 4, half-maximal inhibitory concentration: > 100000 nM
Compound 4: no number, only a limit; the forecaster's own chance of this, stated with the estimate: 60%; the middle value sits exactly at the limit.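

In this assay compound 4 gives > 100000 nM, a limit and not a number, so the change from bromo to fluoro on this aromatic carbon leaves the compound at the same limit: the limit of > 100000 nM in this assay, at which 3 of the 4 values shown sit. The steps to compound 4 from compound 3 and from compound 1 cannot be read, as both ends of each are limits. The one readable step is an at least 2.1-fold higher number from compound 2 to compound 4 (0.33 log units; beyond the scatter), so of the three groups shown on this aromatic carbon, only tert-butyl gives a measured number.

Going by these compounds, whether fluoro and bromo differ at all stays open, as neither compound gives a number in this assay. Also open, on these data alone, is what an amine, a carboxylic acid or a longer alkyl chain on this aromatic carbon would give.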